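Swapping One Aryl Group in Three Cell-Growth Inhibitors

The compounds below may be only part of what the source reports. "The series", "measured", "known", "first", "only" and "open" are said of these compounds alone.

Three compounds have been tested in a functional assay on HeLa cells (Homo sapiens) for inhibition, read by MTT assay, with a stated time of 72 h; on this read-out higher numbers stand for weaker inhibition and lower numbers for stronger inhibition:

compound 1 `CN(C(=O)NC(=O)c1cccc(C(F)(F)F)c1)c1nc(C(F)(F)F)c(C(=O)N/N=C/c2ccccc2C(F)(F)F)s1` gives 7.37 ug/mL
compound 2 `CN(C(=O)NC(=O)c1ccccc1F)c1nc(C(F)(F)F)c(C(=O)N/N=C/c2ccccc2C(F)(F)F)s1` gives 10.1 ug/mL
compound 3 `CN(C(=O)NC(=O)c1ccccc1F)c1nc(C(F)(F)F)c(C(=O)N/N=C/c2cccc(C(F)(F)F)c2)s1` gives 19.1 ug/mL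

Compound 2 and compound 3 are built from the same atoms joined differently: 3-(trifluoromethyl)phenyl in place of 2-(trifluoromethyl)phenyl on a carbon with a double bond to nitrogen. The result is a 1.9-fold higher number from compound 2 to compound 3 (0.28 log units; within the scatter). Compound 1 differs from compound 2 by 3-(trifluoromethyl)phenyl in place of 2-fluorophenyl on a carbonyl carbon, which produced a 1.4-fold lower number from compound 2 to compound 1 (0.14 log units; within the scatter). Compound 4 `CN(C(=O)NC(=O)c1cccc(C(F)(F)F)c1)c1nc(C(F)(F)F)c(C(=O)N/N=C/c2cccc(C(F)(F)F)c2)s1` has not yet been measured. It differs from compound 3 by 3-(trifluoromethyl)phenyl in place of 2-fluorophenyl on a carbonyl carbon, the same change, at the same place, as between compound 2 and compound 1. A similarly small step is therefore expected from compound 3 to compound 4, a 1.4-fold lower number from compound 3 to compound 4 (0.15 log units; within the scatter), because a 1.4-fold lower number from compound 2 to compound 1 (0.14 log units; within the scatter) stayed within the scatter; this rests on one pair only. Compound 4 is expected to give about 13.5 ug/mL, plausibly between 7 ug/mL and 27 ug/mL.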

Compound 4, half-maximal inhibitory concentration: 4.81 ug/mL
The estimate for compound 4 lay 2.8-fold (0.45 log units) above the measured number; measured number below the stated range.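

In this assay, 3-(trifluoromethyl)phenyl in place of 2-fluorophenyl on a carbonyl carbon gives a 4.0-fold lower number from compound 3 to compound 4 (0.60 log units; beyond the scatter), and this step does not match the same change on the other core: the same change on two cores in this assay, a 1.4-fold lower number (0.14 log units; within the scatter) from compound 2 to compound 1 and a 4.0-fold lower number (0.60 log units; beyond the scatter) from compound 3 to compound 4, 2.9-fold (0.46 log units) apart, beyond the scatter of two such steps. The change from 2-(trifluoromethyl)phenyl to 3-(trifluoromethyl)phenyl on a carbon with a double bond to nitrogen gives a 1.5-fold lower number from compound 1 to compound 4 (0.19 log units; within the scatter), and it too fails to carry over unchanged: the same change on two cores in this assay, a 1.9-fold higher number (0.28 log units; within the scatter) from compound 2 to compound 3 and a 1.5-fold lower number (0.19 log units; within the scatter) from compound 1 to compound 4, 2.9-fold (0.46 log units) apart, beyond the scatter of two such steps. Among these four compounds, the size of each step therefore depends on the group at the other place, but two pairs per change do not show why, or whether this holds beyond these compounds.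

The compounds shown leave open how these steps would run with a plain phenyl ring, or a phenyl ring carrying a carboxylic acid, on the carbonyl carbon.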